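Dropping a Fluoro Group: From Measured Step to Expectation

The source may hold more compounds than are shown below. What is called first, only, known or untested is meant among the compounds shown, and "the series" means these compounds.

Compound 1, `COc1ccc(-c2ccc(C(=O)N[C@H]3C[C@@H](N=C=S)C3)nc2)cc1F`, gives 26.6 nM in an assay on isolated protein for inhibition of N-acylethanolamine-hydrolyzing acid amidase (Homo sapiens), read by fluorescence, with a stated time of 90 min; on this read-out lower numbers stand for stronger inhibition and higher numbers for weaker inhibition.
Compound 2, `COc1ccc(-c2ccc(S(=O)(=O)N[C@H]3C[C@@H](N=C=S)C3)cc2)cc1F`, gives 3.2 nM in this assay.
Compound 3, `COc1ccc(-c2ccc(C(=O)N[C@H]3C[C@@H](N=C=S)C3)nc2)cc1`, gives 7.6 nM in this assay.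

Compound 1 and compound 3 share a core and differ in one place: hydrogen in place of fluoro on an aromatic carbon. That change gave a 3.5-fold lower number from compound 1 to compound 3 (0.54 log units; beyond the scatter). Compound 2 stands lowest of the three measured numbers; the difference between its core and the core of compound 1 is not broken down here. Compound 4, `COc1ccc(-c2ccc(S(=O)(=O)N[C@H]3C[C@@H](N=C=S)C3)cc2)cc1`, has not yet been measured. It differs from compound 2 by the same change as seen before, (hydrogen in place of fluoro on an aromatic carbon), at a place described in the same words. Resting on the earlier step of a 3.5-fold lower number from compound 1 to compound 3 (0.54 log units; beyond the scatter), a step of similar size is expected here: a 2.5-fold lower number from compound 2 to compound 4 (0.39 log units; beyond the scatter). Compound 4 is therefore estimated at 1.3 nM, most likely between 0.5 nM and 4 nM.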

Compound 4, half-maximal inhibitory concentration: 2.3 nM
Beside the measured number, compound 4's estimate is 1.8-fold (0.25 log units) below it; low and high end bracket the measured number.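

On the core of compound 2, hydrogen in place of fluoro gives a 1.4-fold lower number from compound 2 to compound 4 (0.14 log units; within the scatter) in this assay, so on this core the effect of the swap cannot be told apart from the ordinary spread of repeated measurements. Set beside the earlier step, the two results do not differ by more than that spread allows: the same change on two cores in this assay, a 3.5-fold lower number (0.54 log units; beyond the scatter) from compound 1 to compound 3 and a 1.4-fold lower number (0.14 log units; within the scatter) from compound 2 to compound 4, 2.5-fold (0.40 log units) apart, within the scatter of two such steps. The data therefore allow the change to carry over from one core to the other at a similar size, but they do not prove it: one step lies beyond the scatter, the other within it, and only two cores are shown.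

The compounds shown leave open how a chloro or methyl group would compare with fluoro and hydrogen at this place on the ring. They also leave open how the same swap would behave on further cores.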